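The source may hold more compounds than are shown below. What is called first, only, known or untested is meant among the compounds shown, and "the series" means these compounds.

Measured compounds in an assay on DDT1 cells (Cricetulus griseus) for binding affinity to adenosine receptor A1 (Homo sapiens), read by radioligand binding; a lower number here means a stronger inhibitor, a higher number a weaker inhibitor: compound 1 `CC/N=C(\S)OC[C@H]1OC(n2cnc3c(NC4CCOC4)nc(Cl)nc32)[C@H](O)[C@@H]1O` gives 55 nM; compound 2 `CCCCNC(=O)OC[C@H]1OC(n2cnc3c(NC4CCOC4)ncnc32)[C@H](O)[C@@H]1O` gives 1410 nM; compound 3 `O=C(NC1CCCC1)OC[C@H]1OC(n2cnc3c(NC4CCOC4)nc(Cl)nc32)[C@H](O)[C@@H]1O` gives 226 nM.

Compound 2 stands highest of the three numbers in this assay, weaker than compound 3 and far weaker than compound 1. Compound 4 `O[C@@H]1[C@@H](CO/C(S)=N/C2CCCCC2)OC(n2cnc3c(NC4CCOC4)ncnc32)[C@@H]1O` arises from compound 2 by the change (a group of 9 heavy atoms (7 carbon, 1 nitrogen, 1 sulfur; one six-membered non-aromatic ring of carbon only) in place of a group of 7 heavy atoms (5 carbon, 1 nitrogen, 1 oxygen; no ring), on an oxygen on a saturated carbon). For the measured compounds named here, the one measured step that bears on it runs the other way: a 4.1-fold higher number from compound 1 to compound 3 (0.61 log units; beyond the scatter), where a sulfur-containing group without a ring was replaced by an oxygen-containing group with a ring. Compound 2 and compound 3 differ in two places, so their values only show the ring-bearing carbamate on the unchlorinated core is weaker. On this basis a step to a lower number is expected in this assay: for compound 4 the estimate is 400 nM, range 100 nM to 1500 nM, a step of a 3.5-fold lower number from compound 2 to compound 4 (0.55 log units; beyond the scatter).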

Compound 4, inhibition constant: 253 nM
Estimate against measurement, compound 4: 1.6-fold (0.20 log units) above; the measured number falls inside the stated range.
By their numbers in this assay, from the lowest: compound 1; then compounds 3 and 4 (each within the scatter of the next); then compound 2.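

In this assay, replacing the butylcarbamoyl group with the sulfur-containing group carrying a six-membered carbon ring, on an oxygen on a saturated carbon, gives a 5.6-fold lower number from compound 2 to compound 4 (0.75 log units; beyond the scatter). With a 4.1-fold higher number from compound 1 to compound 3 (0.61 log units; beyond the scatter), this means that the sulfur-containing group has the lower number in both single-place steps shown, on two different cores, and no compound here goes against that. No measurement here explains this difference. The sulfur and the ring enter together in compound 4, so their contributions remain unseparated. A cyclohexylcarbamoyl group on the same oxygen would help to distinguish them.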